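The source may hold more compounds than are shown below. What is called first, only, known or untested is meant among the compounds shown, and "the series" means these compounds.

Measured so far:
compound 1 `CCNC(=O)CC1CCc2cc(OC)c(OC)cc21` — 26.1%
compound 2 `COc1cc2c(cc1OC)C(CC(=O)NC(C)C)CC2` — 30.4%

Both figures come from a functional assay on the whole organism (strain Wistar) for inhibition, with Rattus norvegicus as the target, read by paw edema, with stated times of 60 min and 3 h, at a dose of 100 mg/kg by the oral route; on this read-out lower numbers stand for less inhibition and higher numbers for more inhibition at the one dose given (going by the name of the read-out). Among the compounds with values here, compound 2 carries the higher of the two numbers only nominally: its one neighbour, compound 1, sits a number 4.3 percentage points higher from compound 1 to compound 2 (within the scatter), a gap within the scatter, so the two cannot be told apart on these data.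

The next compound, compound 3 `COc1cc2c(cc1OC)C(CC(=O)NC(C)(C)C)CC2`, differs from compound 2 in a single place: methyl in place of hydrogen on a saturated chain carbon bound to an amide-type nitrogen and two saturated chain carbons. Cut one bond further out, the same change reads isopropylcarbamoyl to (tert-butyl)carbamoyl.

Within the data shown here, the only measured step that bears on it is the earlier methyl-for-hydrogen change on a saturated chain carbon bound to an amide-type nitrogen, a number 4.3 percentage points higher from compound 1 to compound 2 (within the scatter), which stayed within the scatter. No second methyl at such a position has been measured in the series, so nothing beyond the scatter can be expected in this assay, at most a slight rise of the same order. The inhibition of compound 3 is therefore estimated at 32%, with a range of 18% to 46%. That estimate amounts to an expected step of a number 1.6 percentage points higher from compound 2 to compound 3 (within the scatter), within the scatter.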

Compound 3, a percentage reported as inhibition, in the whole organism at one dose (the size of the read-out at that dose, not a potency): 33.3%
For compound 3 the middle estimate is 1.3 percentage points below the measured one; the measured number falls inside the stated range.
By their numbers in this assay, from the lowest: compounds 1, 2 and 3 (each within the scatter of the next).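

In this assay, a further methyl on the saturated chain carbon bound to an amide-type nitrogen and two saturated chain carbons stays within the scatter (a number 2.9 percentage points higher from compound 2 to compound 3 (within the scatter)), so isopropyl and tert-butyl cannot be told apart at this position. Within the data shown here, the larger replacement, tert-butyl in place of ethyl on an amide-type nitrogen, also stays within the scatter (a number 7.2 percentage points higher from compound 1 to compound 3 (within the scatter)), so ethyl, isopropyl and tert-butyl on this nitrogen all remain indistinguishable on this read-out at the one dose given, which the single earlier step could not show. Nothing available on these compounds gives a reason for this flat result.

Still open, on these data alone, is whether any group on this nitrogen can separate itself from these three alkyl groups beyond the scatter, for instance a longer chain such as n-hexyl, a benzyl group, or a chain ending in a carboxylic acid or an amine. The compounds shown also leave open what happens when the amide hydrogen is replaced by methyl, and whether the shared core contributes to the inhibition seen here.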